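Extending the Saturated Chain Once More

This account rests on a few compounds, and the source may have more. Where it says the series, first, only, none or still open, it means among the compounds named here.

In an ADME assay on Vero cells (Chlorocebus sabaeus) for cytotoxicity, read by MTT assay (on this read-out higher numbers stand for weaker inhibition and lower numbers for stronger inhibition), compound 1 (`CCCCCCCCCC(=O)OCC(C)(C)CC1=C(O)C(=O)c2ccccc2C1=O`) gives 203000 nM and compound 2 (`CCCCCCCCCCCC(=O)OCC(C)(C)CC1=C(O)C(=O)c2ccccc2C1=O`) gives 249000 nM as its value, so these two lie within the scatter of each other. Compound 3 (`CCCCCCCCCCCCCC(=O)OCC(C)(C)CC1=C(O)C(=O)c2ccccc2C1=O`) differs from compound 2 by ethyl in place of hydrogen on a saturated chain carbon, ten or more bonds along the chain from a carbonyl carbon with ethyl in place of hydrogen on a saturated chain carbon. Going by the values given here, the only measured step of this kind was a 1.2-fold higher number from compound 1 to compound 2 (0.09 log units; within the scatter) and lay within the scatter. The expected 1.1-fold higher number from compound 2 to compound 3 (0.04 log units; within the scatter) is therefore no step beyond the scatter in this assay at all. For compound 3 the estimated value is 270000 nM (150000 nM to 480000 nM).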

Compound 3, half-maximal inhibitory concentration: 58400 nM
Estimate against measurement, compound 3: 4.6-fold (0.66 log units) above; measured number outside the range, below it.
By their numbers in this assay, from the lowest: compound 3; then compounds 1 and 2 (each within the scatter of the next).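

In this assay, the same ethyl in place of hydrogen that stayed within the scatter one step earlier now gives a 4.3-fold lower number from compound 2 to compound 3 (0.63 log units; beyond the scatter) at this place, so extending the saturated chain does not act evenly at each step. The butyl change gives a 3.5-fold lower number from compound 1 to compound 3 (0.54 log units; beyond the scatter) across both extensions, and the shift appears only with compound 3. Nothing measured here accounts for this turn.

On these data alone, whether a longer chain would carry the numbers lower still remains open. So does the effect of an amine or a carboxylic acid at the end of the chain.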